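Cytotoxicity limits and a phenyl exchange in the series

The source may report more compounds than this note shows. Statements on the series, on what has been measured and on what is new or still open speak of the compounds shown alone.

Measured so far in an ADME assay on BJ cells (Homo sapiens) for cytotoxicity, with a stated time of 72 h (on this read-out lower numbers stand for an effect already at smaller amounts and higher numbers for an effect only at larger amounts of compound), as follows

compound 1 `COc1cc2ncnc(-n3nc(-c4cccnc4)nc3N)c2cc1OC` gives > 71000 nM
compound 2 `CCOC(=O)CNc1nc(-n2nc(-c3ccccn3)nc2N)c2cc(OC)c(OC)cc2n1` gives > 27000 nM

Compound 2 stands at > 27000 nM and this is a limit of this assay and not a number. Compound 1 also gives only a limit (> 71000 nM) and not a number. Going by the values given here, these two entries set no order between compound 1 and compound 2, and no measured step is available to size a structural change.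

Compound 3 `COc1cc2nc(-c3ccccc3)nc(-n3nc(-c4ccccn4)nc3N)c2cc1OC` departs from compound 2 in one place phenyl in place of ((ethoxycarbonyl)methyl)amino on an aromatic carbon with phenyl in place of ((ethoxycarbonyl)methyl)amino on an aromatic carbon, between two ring nitrogen atoms. The expectation for this exchange rests on compound 2 with its limit (> 27000 nM) and on the absence of any measured number in the series. The estimated change a step that the limit leaves unreadable from compound 2 to compound 3 is expected to stay within the scatter of this assay with no direction favoured. A reported limit is again a likely outcome. For compound 3 the expected value is 30000 nM (estimated range 8000 nM to 90000 nM).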

Compound 3, half-maximal effective concentration: > 27000 nM
Compound 3 gave a limit, no number; the forecaster's own chance of this, stated with the estimate: 60%; the middle value does not contradict the limit.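

In this assay compound 3 gives > 27000 nM, a limit of the assay and not a number. Compound 2 gives > 27000 nM, also a limit, so no step can be read between compound 2 and compound 3. The compounds shown leave open whether phenyl in place of ((ethoxycarbonyl)methyl)amino on an aromatic carbon changes the read-out at all.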